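The source may report more compounds than this note shows. Statements on the series, on what has been measured and on what is new or still open speak of the compounds shown alone.

Compound 1, `COC(=O)C1=C(C)NC(=S)NC1c1ccoc1`, gives 25% in an assay on membranes from CHO cells for displacement of a labelled ligand from adenosine receptor A1 (Homo sapiens), read by scintillation counting, with a stated time of 60 min, tested at 1 uM; a higher number here means more inhibition at the concentration tested (going by the name of the read-out), a lower number less inhibition. Compound 2, `CCCOC(=O)C1=C(C)NC(=S)NC1c1ccoc1`, gives 4% in this assay, and compound 3, `CC1=C(C(=O)OCC(C)C)C(c2ccoc2)NC(=S)N1`, gives 12%. Compound 3 therefore stands second highest of the three numbers: the step of a number 13 percentage points lower from compound 1 to compound 3 (beyond the scatter) lies beyond the scatter, whereas the step of a number 8 percentage points higher from compound 2 to compound 3 (within the scatter) does not. Compound 4, `CC1=C(C(=O)OC(C)(C)C)C(c2ccoc2)NC(=S)N1`, differs from compound 3 in one place: tert-butyl in place of isobutyl on an oxygen next to a carbonyl group. The steps bearing on this are the ones at the oxygen next to the carbonyl group, a number 21 percentage points lower from compound 1 to compound 2 (beyond the scatter) and a number 13 percentage points lower from compound 1 to compound 3 (beyond the scatter), both modest, while the step of a number 8 percentage points higher from compound 2 to compound 3 (within the scatter) rearranges carbons of the chain without effect beyond the scatter. The step of a number 2 percentage points lower from compound 3 to compound 4 (within the scatter) is accordingly expected to stay within the scatter. Compound 4 is estimated at 10%, between 0% and 25%.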

Compound 4, a percentage reported as inhibition, at one concentration (the size of the read-out at that concentration, not a potency): 18%
Beside the measured number, compound 4's estimate is 8 percentage points below it; low and high end bracket the measured number.
By their numbers in this assay, from the lowest: compounds 2, 3, 4 and 1 (each within the scatter of the next, the first and the last beyond it).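

In this assay, tert-butyl on an oxygen next to a carbonyl group stays within the scatter of isobutyl (a number 6 percentage points higher from compound 3 to compound 4 (within the scatter)) and of methyl (a number 7 percentage points lower from compound 1 to compound 4 (within the scatter)), yet stands apart from propyl (a number 14 percentage points higher from compound 2 to compound 4 (beyond the scatter)). Of the three groups compared with methyl at this place, propyl and isobutyl thus go beyond the scatter, while tert-butyl does not. Nothing available accounts for this difference. Going by these compounds, what a benzyl or cyclopropyl group would give on this oxygen stays open, as does whether a carboxylic acid behaves like these groups.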